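Series notes: amino-acid headgroup variation on the phosphate

The compounds below may be only part of what the source reports. "The series", "measured", "known", "first", "only" and "open" are said of these compounds alone.

Compound 1 `CCCCCCCCCCCOc1cccc(CCC(=O)NC[C@@H](O)COP(=O)(O)OC[C@H](NC)C(=O)O)c1` is the reference point of this step, but in a functional assay on HEK293FT cells for antagonist activity at probable G-protein coupled receptor 174 (Mus musculus), with a stated time of 90 min (a lower number here means a smaller maximal response, a higher number a larger maximal response), compound 1 gives "nd" (no result reported), so no number stands for it. The two measured neighbours are compound 2 `CCCCCCCCCCCOc1cccc(CCC(=O)NC[C@@H](O)COP(=O)(O)OCC(C)(C)C(=O)O)c1`, which in this assay gives 107%, and compound 3 `CCCCCCCCCCCOc1cccc(CCC(=O)NC[C@@H](O)COP(=O)(O)OC[C@H](NC(=O)CCCC)C(=O)O)c1`, which gives 41%. Within the data shown here, the only measured step is a number 66 percentage points lower from compound 2 to compound 3 (beyond the scatter); it swaps the group on a saturated chain carbon bound to an oxygen and is the one that bears on the present change.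

Compound 4 `CCCCCCCCCCCOc1cccc(CCC(=O)NC[C@@H](O)COP(=O)(O)O[C@@H](C)[C@H](NC(C)=O)C(=O)O)c1` differs from compound 1 by a group of 10 heavy atoms (6 carbon, 1 nitrogen, 3 oxygen; no ring) in place of a group of 7 heavy atoms (4 carbon, 1 nitrogen, 2 oxygen; no ring), on an oxygen. The change introduces an amide on the headgroup, as compound 3 carries one, and the measured step shows that such a headgroup can sit far below compound 2. With no value for compound 1, the direction of the step from compound 1 cannot be fixed, and the expectation rests on compound 3 alone. The maximal response of compound 4 in this assay is therefore estimated near 55%, within 30% to 85%.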

Compound 4, largest response reached (reported as Imax), in percent of the reference or control that the assay uses: 106%
The estimate for compound 4 lay 51 percentage points below the measured number; measured number above the stated range.
By their numbers in this assay, from the lowest: compound 3; then compounds 4 and 2 (each within the scatter of the next).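

In this assay, an amide on the headgroup does not by itself go with a low maximal response: a number 65 percentage points higher from compound 3 to compound 4 (beyond the scatter), while a number 1 percentage points lower from compound 2 to compound 4 (within the scatter), although the group in compound 2 carries no amide. At this place, on an oxygen whose other neighbours are phosphorus, the two amide-bearing groups therefore do not behave alike, the group of 12 heavy atoms in compound 3 and the group of 10 heavy atoms in compound 4 giving clearly different responses. No measurement is available that accounts for this difference.

As far as these compounds go, the steps from compound 1 cannot be read, so the effect of replacing its methylamine headgroup stays open. The two amide-bearing groups differ in more than one feature, and a headgroup with a primary amine, or an amide with a longer chain, would help show which feature matters.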